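A few compounds are considered here, and "the series" means these few. Any claim that something is new, unique, unknown or untested is made for them only; others in the source may bear on it.

Compound 1 `COc1ccccc1NC(=S)N/N=C/c1ccc2ccccc2n1` was tested in a functional assay on HL-60 cells (Homo sapiens) for antiproliferative activity, read by sulforhodamine B assay, with a stated time of 72 h (on this read-out higher numbers stand for weaker inhibition and lower numbers for stronger inhibition), where compound 1 gives 91700 nM. Among the numbers shown, this is the highest of two. Compound 2 `CN(C)C(=S)N/N=C/c1ccc2cccnc2n1` gives 560 nM in this assay, far lower than compound 1, a gap well beyond the usual scatter. Compound 3 `NC(=S)N/N=C/c1cc2cccnc2s1` reaches only a limit of this assay, > 100000 nM, so no number is known for it. That is the limit of > 100000 nM in this assay, at which 1 of the 3 values shown sits. Compound 4 `Cc1ccccc1NC(=S)N/N=C/c1ccc2ccccc2n1` has not yet been measured. It differs from compound 1 in one place: methyl in place of methoxy on an aromatic carbon. Going by the values given here, no measured pair shows what this exchange does here. A step of a 1.1-fold lower number from compound 1 to compound 4 (0.03 log units; within the scatter) is expected, lying within the scatter. Compound 4 is therefore estimated at 85000 nM, between 30000 nM and 200000 nM.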

Compound 4, half-maximal inhibitory concentration: 73200 nM
Beside the measured number, compound 4's estimate is 1.2-fold (0.06 log units) above it; the measured number falls inside the stated range.
By their numbers in this assay, from the lowest: compound 2; then compounds 4 and 1 (each within the scatter of the next). At a limit, above all of these: compound 3.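

Putting methyl in place of methoxy on this aromatic carbon, ortho to a large group, gives a 1.3-fold lower number from compound 1 to compound 4 (0.10 log units; within the scatter) in this assay. So at this position, losing the oxygen and with it the hydrogen-bond acceptor counted for methoxy leaves the number unchanged within the usual scatter. Nothing measured here bears on why this exchange matters so little. Still open, on these data alone, is whether a clearly different group at this place, such as an amine, a carboxylic acid or a longer chain, would move the number. As far as these compounds go, whether this exchange behaves the same way on another core also remains unknown.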